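Ethyl in Place of Pyrimidinyl on the Piperazine Nitrogen

The source may report more compounds than this note shows. Statements on the series, on what has been measured and on what is new or still open speak of the compounds shown alone.

Compound 1 `COc1ccc(CN2CCN(c3nc(Nc4ccc(C#N)c(C(F)(F)F)c4)nc(Oc4ccnc5ccccc45)n3)CC2)c(OC)c1OC` gives > 100000 nM in a functional assay on DU-145 cells (Homo sapiens) for cytotoxicity, read by sulforhodamine B assay, with a stated time of 48 h; on this read-out lower numbers stand for higher toxicity in this test and higher numbers for lower toxicity in this test; this is a limit of the test, not a number.
Compound 2 `CC(C)N1CCN(c2nc(Nc3ccc(C#N)c(C(F)(F)F)c3)nc(Oc3ccnc4ccccc34)n2)CC1` gives > 100000 nM in this assay, again only a limit.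
Compound 3 `N#Cc1ccc(Nc2nc(Oc3ccnc4ccccc34)nc(N3CCN(c4ncccn4)CC3)n2)cc1C(F)(F)F` gives > 100000 nM in this assay, also a limit.

Compound 3 thus stands where every measured compound stands, at the shared limit (the limit of > 100000 nM in this assay, at which 3 of the 3 values shown sit). The step that the two limits leave unreadable from compound 2 to compound 3 cannot be read, since both ends are limits. Compound 4 `CCN1CCN(c2nc(Nc3ccc(C#N)c(C(F)(F)F)c3)nc(Oc3ccnc4ccccc34)n2)CC1` differs from compound 3 by ethyl in place of pyrimidin-2-yl on an amine nitrogen in a ring. Going by the values given here, the only measured change on that ring nitrogen gave no readable size. Compound 2 carries an isopropyl group on an amine nitrogen in a ring and also sits at the limit. Compound 4 is therefore expected to remain at the limit, with an estimated value of 150000 nM in a range from 60000 nM to 400000 nM. The expected step that the limit leaves unreadable from compound 3 to compound 4 is nothing beyond the scatter.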

Compound 4, concentration lethal to 50% of the cells: > 100000 nM
Compound 4: no number, only a limit; the forecaster's own chance of this, stated with the estimate: 85%; the middle value is on the limit's open side.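

Compound 4 gives only a limit, as do compound 1, compound 2 and compound 3, and no step among these compounds can be read. The compounds shown leave open which group on the ring nitrogen, if any, would give a real number in this assay rather than a limit.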